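Swapping the tert-butylphenyl for a chlorofluorophenyl on the pyridine

The compounds below may be only part of what the source reports. "The series", "measured", "known", "first", "only" and "open" are said of these compounds alone.

Three compounds share one core. In an assay on CHO cells for antagonist activity at transient receptor potential cation channel subfamily V member 1 (Homo sapiens), read by FLIPR (a higher number here means a weaker inhibitor, a lower number a stronger inhibitor), compound 1 `CC(C(=O)NCc1ccc(C(F)(F)F)nc1-c1ccccc1F)c1ccc(NS(C)(=O)=O)c(F)c1` gives 63.3 nM, compound 2 `CC(C(=O)NCc1ccc(C(F)(F)F)nc1-c1ccc(Cl)cc1)c1ccc(NS(C)(=O)=O)c(F)c1` gives 0.7 nM, and compound 3 `CC(C(=O)NCc1ccc(C(F)(F)F)nc1-c1ccc(C(C)(C)C)cc1)c1ccc(NS(C)(=O)=O)c(F)c1` gives 0.5 nM. Compound 3 sits far from compound 1, as a 130-fold lower number from compound 1 to compound 3 (2.10 log units; beyond the scatter) shows, and beside compound 2, since a 1.4-fold lower number from compound 2 to compound 3 (0.15 log units; within the scatter) falls within the scatter. Compound 4 `CC(C(=O)NCc1ccc(C(F)(F)F)nc1-c1ccc(F)c(Cl)c1)c1ccc(NS(C)(=O)=O)c(F)c1` carries 3-chloro-4-fluorophenyl in place of 4-(tert-butyl)phenyl on an aromatic carbon. The steps of a 90-fold lower number from compound 1 to compound 2 (1.96 log units; beyond the scatter) and a 1.4-fold lower number from compound 2 to compound 3 (0.15 log units; within the scatter) bear on this: a 4-chlorophenyl or 4-(tert-butyl)phenyl gives the low numbers, while chloro against tert-butyl changes little. Compound 4 keeps a halogenated phenyl, so in this assay a step no larger than the scatter is expected, a 3.0-fold higher number from compound 3 to compound 4 (0.48 log units; beyond the scatter). Compound 4 is therefore estimated at 1.5 nM, within 0.4 nM to 6 nM.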

Compound 4, inhibition constant: 0.2 nM
The estimate for compound 4 lay 7.5-fold (0.88 log units) above the measured number; measured number below the stated range.
By their numbers in this assay, from the lowest: compound 4; then compounds 3 and 2 (each within the scatter of the next); then compound 1.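

In this assay, 3-chloro-4-fluorophenyl on this aromatic carbon, next to the ring nitrogen, gives a 2.5-fold lower number from compound 3 to compound 4 (0.40 log units; beyond the scatter) and a 3.5-fold lower number from compound 2 to compound 4 (0.54 log units; beyond the scatter), so it improves on both earlier low-number groups, modestly but beyond the scatter. With a 320-fold lower number from compound 1 to compound 4 (2.50 log units; beyond the scatter), it also shows that among these compounds the lowest number does not need a group as large as 4-(tert-butyl)phenyl. No evidence is available to explain this gain.

The compounds shown leave open whether the chloro or the fluoro of the new ring carries the step. They also leave open whether a nitrile or an amine on that phenyl would keep numbers this low.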